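Expecting another limit after the amide substituent change

The source may report more compounds than this note shows. Statements on the series, on what has been measured and on what is new or still open speak of the compounds shown alone.

Compound 1 `O=C(/C=C/c1coc2cc(O)ccc2c1=O)NCc1ccc(F)cc1`, compound 2 `COc1ccc2c(=O)c(/C=C/C(=O)Nc3cccc(Cl)c3)coc2c1` and compound 3 `COc1ccc2c(=O)c(/C=C/C(=O)Nc3ccc(C)cc3)coc2c1` share one core and differ mainly in the group attached to the amide-type nitrogen. In a functional assay on L02 cells (Homo sapiens) for inhibition, read by MTT assay, with a stated time of 48 h (on this read-out lower numbers stand for stronger inhibition and higher numbers for weaker inhibition), compound 1 gives no number, only a limit of > 200000 nM. Compound 2 likewise reaches only a limit in this assay, > 200000 nM. Compound 3 also stands at a limit in this assay, > 200000 nM. All three values therefore sit at the limit of > 200000 nM in this assay, at which 3 of the 3 values shown sit, and the step that the two limits leave unreadable from compound 2 to compound 3 cannot be read, since neither end of it is a number.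

Compound 4 `COc1ccc2c(=O)c(/C=C/C(=O)NCc3cccc(F)c3)coc2c1` is the compound still to be measured. It differs from compound 3 in one place: 3-fluorobenzyl in place of 4-methylphenyl on an amide-type nitrogen. Among the compounds with values here, no measured step bears readably on this change, and compound 1, which also carries a fluorobenzyl on the amide-type nitrogen, stops at the same limit. The expectation is therefore that compound 4 again shows no measurable inhibition in this assay, so the step that the limit leaves unreadable from compound 3 to compound 4 is expected to be none beyond the scatter. Compound 4 is estimated at 250000 nM, with a range from 100000 nM to 700000 nM, most likely reported only as a limit.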

Compound 4, half-maximal inhibitory concentration: > 200000 nM
Compound 4 was reported as a limit (the forecaster's own chance of this, stated with the estimate: 85%); the middle value does not contradict the limit.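

Compound 4 also gives only a limit in this assay, > 200000 nM. With no number at either end, the steps from compound 2 and from compound 3 to compound 4 cannot be read. The compounds shown leave open whether any group on the amide-type nitrogen would give a real number in this assay, and all remain at one value: the limit of > 200000 nM in this assay, at which 4 of the 4 values shown sit.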